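Compound 3: a new group on the shared core

The source may report more compounds than this note shows. Statements on the series, on what has been measured and on what is new or still open speak of the compounds shown alone.

In an ADME assay on MRC5 cells (Homo sapiens) for antiproliferative activity, read by fluorescence and resazurin assay, with a stated time of 68 h (a higher number here means that more compound is needed for the effect, a lower number that less compound is needed), compound 1 `CN1CCN(c2cc(C(=O)NCCN3CCCC3)c3cc(F)ccc3n2)CC1` gives 20000 nM. Compound 2 `O=C(NCCN1CCCC1)c1cc(N2CCn3ccnc3C2)nc2ccc(F)cc12` gives > 50000 nM, which is a limit of the assay and not a number. The next change leads to compound 3 `O=C(NCCN1CCCC1)c1cc(NCCN2CCCCC2)nc2ccc(F)cc12`, and it is a group of 9 heavy atoms (7 carbon, 2 nitrogen; one six-membered non-aromatic ring with 1 hetero atom) in place of a group of 9 heavy atoms (6 carbon, 3 nitrogen; one five-membered aromatic ring with 2 hetero atoms, one six-membered non-aromatic ring with 2 hetero atoms), on an aromatic carbon: (2-(piperidin-1-yl)ethyl)amino enters on the aromatic carbon next to the ring nitrogen. Within the data shown here, the one measured step at this carbon is an at least 2.5-fold higher number from compound 1 to compound 2 (0.39 log units; beyond the scatter), which lies beyond the scatter and is open-ended. Among the measured compounds shown here, no compound with the entering group has been measured, so this single step is a thin guide. It suggests that the group at this carbon can shift the number, and a modest move towards lower numbers is expected. The estimated change is an at least 2.5-fold lower number from compound 2 to compound 3 (0.39 log units; beyond the scatter) in this assay. For compound 3 the expected value is 20000 nM, with an estimated range of 6000 nM to 50000 nM.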

Compound 3, half-maximal effective concentration: 19000 nM
Beside the measured number, compound 3's estimate is 1.1-fold (0.02 log units) above it; the range from low to high includes it.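

In this assay, the group on the aromatic carbon next to the ring nitrogen can move the number back down as well as up: (2-(piperidin-1-yl)ethyl)amino in place of the fused bicyclic group of compound 2 gives a clear return (an at least 2.6-fold lower number from compound 2 to compound 3 (0.42 log units; beyond the scatter)). Against 4-methylpiperazin-1-yl the same group shows no separation (a 1.1-fold lower number from compound 1 to compound 3 (0.02 log units; within the scatter)), so the number at this carbon does not depend on keeping that ring. As far as these compounds go, the size of the first step stays open-ended, as compound 2 stands at a limit of the assay and not at a number: the limit of > 50000 nM in this assay, at which 1 of the 3 values shown sits.

From the compounds shown here alone, whether a shorter chain such as (2-(dimethylamino)ethyl)amino, or a plain amino group, at this carbon would separate from compound 1 and compound 3 remains open. So does the effect of replacing the (2-(pyrrolidin-1-yl)ethyl)carbamoyl group with a carboxylic acid.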